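The compounds below may be only part of what the source reports. "The series", "measured", "known", "first", "only" and "open" are said of these compounds alone.

In a functional assay on A549 cells (Homo sapiens) for cytotoxicity, read by MTT assay, with a stated time of 72 h (a lower number here means a stronger inhibitor, a higher number a weaker inhibitor), compound 3 `CC(=O)n1cc(/C=C(/C(=O)O)c2ccccc2)c2cc(OCc3ccccc3)ccc21` gives 57500 nM. Compound 1 `COc1cc(/C(=C\c2cn(C(C)=O)c3ccc(OCc4ccccc4)cc23)C(=O)O)cc(OC)c1OC` gives 89100 nM, and the step of a 1.5-fold lower number from compound 1 to compound 3 (0.19 log units; within the scatter) lies within the scatter, so the two compounds are not distinguished by this assay. Compound 2 `O=C(O)/C(=C/c1c[nH]c2ccc(OCc3ccccc3)cc12)c1ccccc1` has "not determined" (no result reported) in this assay. Compound 4 `COc1ccc(Cn2cc(/C=C(/C(=O)O)c3ccccc3)c3cc(OCc4ccccc4)ccc32)cc1` differs from compound 3 on the aromatic nitrogen of the five-membered ring: 4-methoxybenzyl in place of acetyl on an aromatic nitrogen. Within the data shown here, no measured step changes a group on that nitrogen; the single measured step alters the group on the double-bonded chain carbon and is itself within the scatter. There is thus no basis for expecting a move beyond the scatter in this assay. Compound 4 is estimated at 40000 nM, between 10000 nM and 150000 nM, the expected step being a 1.4-fold lower number from compound 3 to compound 4 (0.16 log units; within the scatter).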

Compound 4, half-maximal inhibitory concentration: 1000 nM
The estimate for compound 4 lay 40-fold (1.60 log units) above the measured number; the whole stated range lies above it.
By their numbers in this assay, from the lowest: compound 4; then compounds 3 and 1 (each within the scatter of the next).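

In this assay, the aromatic nitrogen of the five-membered aromatic ring proves to be a place where a single change moves the number far: 4-methoxybenzyl in place of acetyl gives a 58-fold lower number from compound 3 to compound 4 (1.76 log units; beyond the scatter) and so lies beyond the scatter. The earlier measured step, made on the double-bonded chain carbon, gave no such move. Nothing shown here accounts for the size of this step. The compounds shown leave open whether a plain benzyl, a methyl or a longer alkyl chain on that nitrogen would give a similarly low number.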